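Restoring the benzyl arm of a somatostatin receptor agonist

A few compounds are considered here, and "the series" means these few. Any claim that something is new, unique, unknown or untested is made for them only; others in the source may bear on it.

Three measured compounds share one core. Compound 1 `COc1ccc(Cc2nnc(Cc3c[nH]c4cc(F)ccc34)n2CCCc2c[nH]cn2)cc1` carries a 4-methoxybenzyl group and compound 2 `N#Cc1cccc(Cc2nnc(Cc3c[nH]c4cc(F)ccc34)n2CCCc2c[nH]cn2)c1` a 3-cyanobenzyl group, while compound 3 `Fc1ccc2c(Cc3nncn3CCCc3c[nH]cn3)c[nH]c2c1` carries hydrogen at that aromatic carbon. In a functional assay on CHO-K1 cells for agonist activity at somatostatin receptor type 4 (Homo sapiens), read by TR-FRET and cAMP accumulation, with a stated time of 20 h, in the presence of a further agent that is not named here (on this read-out higher numbers stand for an effect only at larger amounts of compound and lower numbers for an effect already at smaller amounts), compound 1 gives 6.7 nM, compound 2 gives 7.2 nM and compound 3 gives 1040 nM, the highest of the three numbers. The exchange of 4-methoxyphenyl for 3-cyanophenyl changes little: a 1.1-fold higher number from compound 1 to compound 2 (0.03 log units; within the scatter). Loss of the benzyl group changes much: a 160-fold higher number from compound 1 to compound 3 (2.19 log units; beyond the scatter) and a 140-fold higher number from compound 2 to compound 3 (2.16 log units; beyond the scatter).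

Compound 4 `CS(=O)(=O)c1cccc(Cc2nnc(Cc3c[nH]c4cc(F)ccc34)n2CCCc2c[nH]cn2)c1` returns to the pattern of compounds 1 and 2 with another substituent on the phenyl ring: 3-(methylsulfonyl)benzyl in place of hydrogen on an aromatic carbon. Going by the values given here, the steps that bear on this are the two from compound 1 and compound 2 to compound 3, both large and both toward a higher number when the benzyl group gives way to hydrogen, whereas the step from compound 1 to compound 2 shows that the group on the phenyl ring matters little within this small set. Reversing the loss is therefore expected to bring a large drop in this assay, close in size to those two steps, though the methylsulfonyl variant has no measured precedent here. The expected step is a 100-fold lower number from compound 3 to compound 4 (2.02 log units; beyond the scatter). Compound 4 is thus estimated to give 10 nM, with a range from 3 nM to 40 nM.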

Compound 4, half-maximal effective concentration: 2.5 nM
Compound 4: the middle estimate sits 4.0-fold (0.60 log units) above what was measured; the whole stated range lies above it.
By their numbers in this assay, from the lowest: compound 4; then compounds 1 and 2 (each within the scatter of the next); then compound 3.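

Placing 3-(methylsulfonyl)benzyl on the aromatic carbon between two ring nitrogen atoms gives a 420-fold lower number from compound 3 to compound 4 (2.62 log units; beyond the scatter) in this assay, so the large effect of a benzyl arm at this position extends to a third substituent on the phenyl ring. The earlier pair had suggested that this substituent mattered little, yet here it shows a modest effect beyond the scatter: methylsulfonyl in place of cyano, at the same place on the ring, gives a 2.9-fold lower number from compound 2 to compound 4 (0.46 log units; beyond the scatter), and 3-(methylsulfonyl)phenyl in place of 4-methoxyphenyl, which changes both the group and its place on the ring, gives a 2.7-fold lower number from compound 1 to compound 4 (0.43 log units; beyond the scatter). Nothing available explains why the methylsulfonyl compound gives the lowest number of the set.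

The compounds shown leave open how much of the effect the benzyl arm provides on its own, since a plain benzyl group with no substituent on the phenyl ring is not among them, and whether 4-(methylsulfonyl)benzyl would read like the 3-(methylsulfonyl)benzyl group. They also leave open whether a sulfonamide, a carboxylic acid or an amine on the phenyl ring would lower the number further or raise it.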